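Acetyl in place of 3,4-dichlorobenzyl on compound 3

The compounds below may be only part of what the source reports. "The series", "measured", "known", "first", "only" and "open" are said of these compounds alone.

Measured in a physicochemical assay for solubility, with a stated time of 3 days, at pH 2; a higher number here means a more soluble compound, a lower number a less soluble compound:
Compound 1 `Cc1ccc(CN2CCCCC2CCOc2ccc(-c3nc4cc(C(N)=O)ccc4[nH]3)cc2)cc1`: > 400000 nM (a limit of the assay)
Compound 2 `NC(=O)c1ccc2[nH]c(-c3ccc(OCCC4CCCCN4Cc4ccc(Cl)cc4)cc3)nc2c1`: > 400000 nM (a limit of the assay)
Compound 3 `NC(=O)c1ccc2[nH]c(-c3ccc(OCCC4CCCCN4Cc4ccc(Cl)c(Cl)c4)cc3)nc2c1`: 39000 nM

Most of this short series sits at the limit of > 400000 nM in this assay, at which 2 of the 3 values shown sit. Among the compounds with values here, compound 3, at 39000 nM, gives the only actual number and stands lowest of the three.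

The next compound, compound 4 `CC(=O)N1CCCCC1CCOc1ccc(-c2nc3cc(C(N)=O)ccc3[nH]2)cc1`, carries acetyl in place of 3,4-dichlorobenzyl on an amine nitrogen in a ring.

Within the data shown here, no measured step makes this exact change, and acetyl appears in no measured compound. The nearest evidence concerns the group that leaves. The series shows an at least 10-fold lower number from compound 2 to compound 3 (1.01 log units; beyond the scatter), with chloro in place of hydrogen on an aromatic carbon. It also shows an at least 10-fold lower number from compound 1 to compound 3 (1.01 log units; beyond the scatter), with 3,4-dichlorophenyl in place of 4-methylphenyl. Both steps are large, whereas a step that the two limits leave unreadable from compound 1 to compound 2 gives no readable size.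

Given an at least 10-fold lower number from compound 2 to compound 3 (1.01 log units; beyond the scatter), and since compound 4 no longer has that chlorinated aromatic ring, a large upward step is expected in this assay. The expected change is a 5.1-fold higher number from compound 3 to compound 4 (0.71 log units; beyond the scatter). For compound 4 the estimated value is 200000 nM, with an expected range from 50000 nM to 400000 nM.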

Compound 4, solubility: > 400000 nM
Compound 4 ended at the assay's limit; the forecaster's own chance of this, stated with the estimate: 35%; middle value at least 2.0-fold (0.30 log units) away from the limit.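

In this assay, within the data shown here, the earlier steps changed only what sits on the aromatic ring of the benzyl group, whereas acetyl in place of 3,4-dichlorobenzyl on the amine nitrogen in a ring removes that ring altogether and gives an at least 10-fold higher number from compound 3 to compound 4 (1.01 log units; beyond the scatter). Compound 4 gives > 400000 nM, which is a limit of the assay. The position therefore takes a much smaller group without any aromatic ring, and among the four compounds only the one carrying 3,4-dichlorobenzyl gives an actual number, while acetyl stands with 4-methylbenzyl and 4-chlorobenzyl: the limit of > 400000 nM in this assay, at which 3 of the 4 values shown sit.

The steps to compound 4 from compound 1 and from compound 2 cannot be read, so any order among these three stays open, as does how far each lies past the limit. The compounds shown also leave open how benzoyl on this nitrogen, which would keep an aromatic ring together with the carbonyl of acetyl, would stand in this assay against 3,4-dichlorobenzyl and acetyl.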